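The compounds below may be only part of what the source reports. "The series", "measured", "known", "first", "only" and "open" are said of these compounds alone.

Compound 1, `CC1(C)Oc2ccc(C#N)cc2[C@@H](n2c(O)nc3ccccc32)[C@@H]1O`, in a functional assay (aorta) with Rattus norvegicus as the target; a lower number here means a stronger inhibitor, a higher number a weaker inhibitor: 41000 nM
Compound 2, `CC1(C)Oc2ccc(C#N)cc2[C@@H](N2CCN(c3ccccc3)C2=O)[C@@H]1O`, in this assay: 23700 nM
Compound 3, `CC1(C)Oc2ccc(C#N)cc2[C@@H](/N=C(\NC#N)Nc2ccc(C(F)(F)F)cc2)[C@@H]1O`, in this assay: 8100 nM

Three compounds share the core and differ only in the group on the benzylic carbon. Of the three, compound 3 gives the lowest number in this assay; the gap to compound 2 and the gap to compound 1 both lie beyond the usual scatter of repeated measurements, so compound 3 stands as the strongest inhibitor of the three on the numbers available, though its value is still in the weak range.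

Compound 4, `CC1(C)Oc2ccc(C#N)cc2[C@@H](/N=C(\NC#N)Nc2ccc3c(c2)CCC3)[C@@H]1O`, has not yet been measured. It keeps the cyanoguanidine arm of compound 3 and differs from it only in one place: 2,3-dihydro-1H-inden-5-yl in place of 4-(trifluoromethyl)phenyl on an amine nitrogen. Among the compounds with values here, no single-change step between measured compounds is available to calibrate this kind of swap, so the expectation rests on compound 3 alone. Both groups are uncharged aromatic groups with no donors or acceptors, and the change is expected to move the number little, with any step staying within or only slightly beyond the scatter in either direction. The expected step is a 1.0-fold lower number from compound 3 to compound 4 (0.01 log units; within the scatter). Compound 4 is estimated at 8000 nM, within a range from 2500 nM to 25000 nM.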

Compound 4, half-maximal inhibitory concentration: 41300 nM
Compound 4: middle estimate off by 5.2-fold (0.71 log units), on the low side, and the stated range ends below it.
By their numbers in this assay, from the lowest: compound 3; then compounds 2, 1 and 4 (each within the scatter of the next).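

In this assay, the aryl group on the amine nitrogen of the cyanoguanidine arm proves not to be freely interchangeable: 2,3-dihydro-1H-inden-5-yl in place of 4-(trifluoromethyl)phenyl gives a 5.1-fold higher number from compound 3 to compound 4 (0.71 log units; beyond the scatter), which means weaker inhibition. Within the data shown here, this is the first single-place step, and it shows that this position responds to the choice of aryl group even when the leaving and entering groups are both uncharged and both carry no hydrogen-bond donors or acceptors. No measurement at hand bears on the reason for this step.

The compounds shown do not separate the loss of the trifluoromethyl group from the gain of the five-membered non-aromatic ring, a question that a plain phenyl, a 4-methylphenyl or a 4-chlorophenyl on the same nitrogen would address. As far as these compounds go, it also remains open whether the same swap gives a step of similar size on a different arm, such as a urea or thiourea in place of the cyanoguanidine.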